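Inverting the Single Stereocentre of Compound 2

The source may hold more compounds than are shown below. What is called first, only, known or untested is meant among the compounds shown, and "the series" means these compounds.

In a functional assay on the whole organism (arterial blood) with Rattus norvegicus as the target (a higher number here means that more compound is needed for the effect, a lower number that less compound is needed), compound 1 (`Cc1nc2cnccc2n1CC1CCN(C(=O)CC(C)c2ccccc2)CC1`) gives 0.033 mg/kg and compound 2 (`Cc1nc2cnccc2n1CC1CCN(C(=O)N[C@H](C)c2ccccc2)CC1`) gives 0.017 mg/kg. For the measured compounds named here, the only measured step is a 1.9-fold lower number from compound 1 to compound 2 (0.29 log units; within the scatter), so these two values lie within the scatter of each other. Compound 3 (`Cc1nc2cnccc2n1CC1CCN(C(=O)N[C@@H](C)c2ccccc2)CC1`) is related to compound 2 as follows: the two compounds have the same atoms and bonds and differ only in configuration as drawn: 1 of 1 stereo elements differ; a stereocentre at a saturated chain carbon is drawn R in compound 2 and S in compound 3. That measured step exchanges a group on a carbonyl carbon and does not test configuration, so it gives no direct guide to the size of this change. Going by the values given here, no measured pair isolates configuration, and the data fix no direction. A move towards a higher number is assumed here, but only tentatively. The expected change is a 2.9-fold higher number from compound 2 to compound 3 (0.47 log units; beyond the scatter), an estimate that carries wide uncertainty. For compound 3 the estimated value is 0.05 mg/kg, with an expected range from 0.012 mg/kg to 0.25 mg/kg.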

Compound 3, dose for 50% inhibition: 0.21 mg/kg
Estimate against measurement, compound 3: 4.2-fold (0.62 log units) below; low and high end bracket the measured number.
By their numbers in this assay, from the lowest: compounds 2 and 1 (each within the scatter of the next); then compound 3.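

In this assay, for the compounds shown here, the configuration at the saturated chain carbon carries far more weight than the earlier exchange on the carbonyl carbon did, with a 12-fold higher number from compound 2 to compound 3 (1.09 log units; beyond the scatter) where the only earlier step lay within the scatter. The exchange of 2-phenylpropyl for (1-phenylethyl)amino now also reads differently by configuration: the R form, compound 2, stays within the scatter of compound 1, whereas the S form gives a 6.4-fold higher number from compound 1 to compound 3 (0.80 log units; beyond the scatter). The gap between the two forms can be assigned to configuration alone because of one thing: the fact that compounds 2 and 3 differ only in the configuration as drawn.

The compounds shown leave open whether the same preference for R holds when an ethyl group takes the place of the methyl at this stereocentre. They also leave open how the separate configurations of the 2-phenylpropyl group of compound 1 compare, since that centre is drawn without configuration.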